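Removing the Amino Group from Compound 1

The source may report more compounds than this note shows. Statements on the series, on what has been measured and on what is new or still open speak of the compounds shown alone.

All values here come from an assay for inhibition of MAP kinase-interacting serine/threonine-protein kinase 2 (Homo sapiens), read by luminescence and ADP-Glo, with a stated time of 2 h; on this read-out higher numbers stand for weaker inhibition and lower numbers for stronger inhibition.
Compound 1, `Nc1n[nH]c2cc(-c3ccc(=O)n(Cc4ccccc4F)c3)ccc12`: 4 nM
Compound 3, `Nc1n[nH]c2cc(-c3ccc(=O)n(Cc4cccc(F)c4)c3)ccc12`: 5 nM
Compound 2, `Cn1cc2ccc(-c3ccc(=O)n(Cc4ccccc4)c3)cc2n1`: > 2000 nM, a limit of the assay rather than a number

Compound 1 holds the lowest of the two numbers. Its nearest neighbour is compound 3, and the step of a 1.3-fold higher number from compound 1 to compound 3 (0.10 log units; within the scatter) puts 3-fluorophenyl in place of 2-fluorophenyl on a saturated chain carbon bound to an aromatic nitrogen, with no change beyond the scatter. Compound 2 reaches only the limit of > 2000 nM in this assay, at which 1 of the 3 values shown sits, in this assay.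

Compound 4, `O=c1ccc(-c2ccc3cn[nH]c3c2)cn1Cc1ccccc1F`, differs from compound 1 in one place: hydrogen in place of amino on an aromatic carbon. Within the data shown here, no measured step covers this change. Among the measured compounds shown here, the only measured step, from compound 1 to compound 3, alters the fluorophenyl and not the amino group, so it does not bear on the present question. Compound 2 also lacks the amino group, although its core differs further by a methyl on a ring nitrogen and by a benzyl without fluorine.

Given that compound 2 sits at a limit, a clear weakening is expected for compound 4, estimated as a 75-fold higher number from compound 1 to compound 4 (1.88 log units; beyond the scatter). Compound 4 is therefore expected at 300 nM, with a range from 40 nM to 2000 nM.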

Compound 4, half-maximal inhibitory concentration: 37 nM
Compound 4: the middle estimate sits 8.1-fold (0.91 log units) above what was measured; measured number outside the range, below it.
By their numbers in this assay, from the lowest: compounds 1 and 3 (each within the scatter of the next); then compound 4. At a limit, above all of these: compound 2.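

The amino group on this aromatic carbon of the five-membered ring matters, but inhibition does not depend on it entirely: replacing it with hydrogen gives a 9.3-fold higher number from compound 1 to compound 4 (0.97 log units; beyond the scatter), a modest step that lies beyond the scatter. Among these compounds, compound 4 still gives 37 nM with no amino group, so the loss of this group alone does not abolish inhibition, something the earlier compounds could not show, as the only step among them moved the fluorine on the phenyl ring. Which feature of the amino group accounts for the step is not told by anything measured here.

As far as these compounds go, whether a methyl, a hydroxyl or a methylamino group on this carbon would give a number closer to that of compound 1 or to that of compound 4 remains open. From the compounds shown here alone, compound 2, whose value is a limit, differs from compound 4 in more than one place, so what its methyl on a ring nitrogen does on its own also stays open.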